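The source may hold more compounds than are shown below. What is called first, only, known or untested is meant among the compounds shown, and "the series" means these compounds.

The three measured compounds share one core and differ only in what sits on the amide-type nitrogen. Compound 1 `COC(=O)CCNC(=O)[C@@H]1CC=C(CCC=C(C)C)C[C@H]1c1ccccc1` carries a 2-(methoxycarbonyl)ethyl chain on that nitrogen; in an assay on isolated protein for inhibition of Apoptosis regulator Bcl-2 (Homo sapiens), read by fluorescence polarization, with stated times of 5 min and 10 min (on this read-out lower numbers stand for stronger inhibition and higher numbers for weaker inhibition), compound 1 gives only a limit of > 23000 nM. Compound 2 `CC(C)=CCCC1=CC[C@@H](C(=O)NCCC(=O)O)[C@H](c2ccccc2)C1` carries a 2-carboxyethyl chain instead. In this assay compound 2 likewise gives only a limit of > 23000 nM. Compound 3 `CC(C)=CCCC1=CC[C@@H](C(N)=O)[C@H](c2ccccc2)C1` has the bare carbamoyl group. In this assay compound 3 also gives only a limit of > 23000 nM. Compound 3 therefore stands exactly where the other two stand, at the limit of > 23000 nM in this assay, at which 3 of the 3 values shown sit. The steps between them cannot be sized: a step that the two limits leave unreadable from compound 1 to compound 2, a step that the two limits leave unreadable from compound 1 to compound 3 and a step that the two limits leave unreadable from compound 2 to compound 3 all run from one limit to another.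

Compound 4 `CON(C)C(=O)[C@@H]1CC=C(CCC=C(C)C)C[C@H]1c1ccccc1` is not yet measured. It differs from compound 3 by methoxy(methyl)amino in place of amino on a carbonyl carbon. All three measured steps alter the same amide-type nitrogen, yet none of them has a readable size, so they give no direction for this change. With every shown value sitting at the limit, compound 4 is expected to come out at or near that same limit in this assay, which means an expected step that the limit leaves unreadable from compound 3 to compound 4. The estimate for compound 4 is 35000 nM, with a range from 10000 nM to 120000 nM.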

Compound 4, inhibition constant: > 23000 nM
Compound 4 ended at the assay's limit; the forecaster's own chance of this, stated with the estimate: 80%; the middle value lies beyond the limit too.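

Going by these compounds alone, no step from compound 4 to compound 1, compound 2 or compound 3 can be read, because each pair runs from one limit to another: the limit of > 23000 nM in this assay, at which 4 of the 4 values shown sit. The compounds shown leave open how strongly any of them actually inhibits in this assay, and whether any group on this carbonyl carbon changes that inhibition at all.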